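Lengthening the ester chain of compound 3

This account rests on a few compounds, and the source may have more. Where it says the series, first, only, none or still open, it means among the compounds named here.

In an ADME assay on HepG2 2.2.15 cells (Homo sapiens) for cytotoxicity (a lower number here means that less compound is tolerated, a higher number that more compound is tolerated), compound 1 (`Cn1c(=O)c(CCO)c(-c2ccccc2Cl)c2cc(Cl)ccc21`) gives 34000 nM. Compound 2 (`O=c1c(CCO)c(-c2ccccc2Cl)c2cc(Cl)ccc2n1-c1c(F)cccc1F`) reaches only a limit of the assay, > 2300000 nM. Compound 3 (`CC(=O)OCCc1c(-c2ccccc2Cl)c2cc(Cl)ccc2[nH]c1=O`) gives 27000 nM, a value within the scatter of that of compound 1.

Compound 4 (`CCCCCCCC(=O)OCCc1c(-c2ccccc2Cl)c2cc(Cl)ccc2[nH]c1=O`) differs from compound 3 as hexyl in place of hydrogen on a saturated chain carbon bound to a carbonyl carbon, which turns acetoxy into (heptylcarbonyl)oxy. For the measured compounds named here, the only measured step, an at least 67-fold higher number from compound 1 to compound 2 (1.83 log units; beyond the scatter), is large, but it is a change on an aromatic nitrogen. Going by the values given here, no measured step involves a saturated chain carbon bound to a carbonyl carbon, so that step gives no size or direction for this change. No step beyond the scatter is therefore expected in this assay, and the expectation stays anchored on compound 3 at 27000 nM. The estimated step is no change at the digits printed from compound 3 to compound 4 (within the scatter). The range is kept wide because the only anchor is a single value. For compound 4 the expected value is 27000 nM, with an estimated range of 8000 nM to 100000 nM.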

Compound 4, half-maximal cytotoxic concentration: 78000 nM
Compound 4: middle estimate off by 2.9-fold (0.46 log units), on the low side; the measured number falls inside the stated range.
By their numbers in this assay, from the lowest: compounds 3 and 1 (each within the scatter of the next); then compound 4. At a limit, above all of these: compound 2.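

The ester chain is a position that responds in this assay: a 2.9-fold higher number from compound 3 to compound 4 (0.46 log units; beyond the scatter). For the compounds shown here, this gives the series its first read on hexyl in place of hydrogen on a saturated chain carbon bound to a carbonyl carbon, with a modest step towards a higher number, whereas the earlier compounds gave no size or direction for a change at this place. Nothing shown gives a reason for this step.

From the compounds shown here alone, whether the number keeps rising with a chain longer than heptylcarbonyl, or changes with an amine or a carboxylic acid at the end of the chain, stays open. Going by these compounds, the direction rests on one pair, so it is also open whether the same change would go the same way with the methyl or the 2,6-difluorophenyl group on the aromatic nitrogen.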